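The source may hold more compounds than are shown below. What is called first, only, known or untested is meant among the compounds shown, and "the series" means these compounds.

Of the compounds shown here, three sharing one core have been measured in an in vitro ADME assay on microsomes from liver (Mus musculus) for metabolic stability, read by LC-MS, tested at 1 uM (a higher number here means that the compound lasts longer, a lower number that the compound disappears faster), and every one of them sits at a limit. Compound 1 `CCC(CC)C(=O)N/C(=N/c1nccn1C(C)C)Nc1ccc(Cl)c(Cl)c1` gives > 1 h, which is a limit of the assay and not a number. Compound 2 `CC(C)n1ccnc1/N=C(/NC(=O)C(C)(C)C)Nc1ccc(Cl)c(Cl)c1` gives > 1 h, again a limit. Compound 3 `CC(C)(C)C(=O)N/C(=N/c1nccn1C(C)(C)C)Nc1ccc(Cl)c(Cl)c1` gives > 1 h, also a limit, so its standing can only be described as at or beyond the edge of what this assay reports. Because all three values sit at the limit of > 1 h in this assay, at which 3 of the 3 values shown sit, the measured steps a step that the two limits leave unreadable from compound 1 to compound 2 and a step that the two limits leave unreadable from compound 2 to compound 3 cannot be sized in either direction.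

Compound 4 `CCC(CC)C(=O)N/C(=N/c1nccn1C(C)(C)C)Nc1ccc(Cl)c(Cl)c1` differs from compound 3 in one place: pentan-3-yl in place of tert-butyl on a carbonyl carbon. Within the data shown here, the only measured step touching the same position is a step that the two limits leave unreadable from compound 1 to compound 2, which runs the other way and is unreadable, so no direction is indicated. The expected step in this assay is therefore a step that the limit leaves unreadable from compound 3 to compound 4, nothing beyond the scatter. Compound 4 is estimated at 1.5 h, within 0.7 h to 3 h.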

Compound 4, half-life: 0.208 h
For compound 4 the middle estimate is 7.2-fold (0.86 log units) above the measured one, outside the stated range (below it).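

Pentan-3-yl in place of tert-butyl on the carbonyl carbon is not a silent change in this assay: it gives an at least 4.8-fold lower number from compound 3 to compound 4 (0.68 log units; beyond the scatter). The added methyl gives a drop of its own, an at least 4.8-fold lower number from compound 1 to compound 4 (0.68 log units; beyond the scatter). Compound 1 and compound 3 each carry only one of these two changes and both remain at the limit of the assay, so among these compounds a readable fall appears only where pentan-3-yl and the extra methyl occur together, in compound 4.

On these data alone, the steps among compound 1, compound 2 and compound 3 cannot be read, and how far these three lie past the limit stays unknown: the limit of > 1 h in this assay, at which 3 of the 4 values shown sit. Also open, as far as these compounds go, is whether a straight pentyl chain or a cyclohexyl group on the carbonyl carbon would behave like pentan-3-yl or like tert-butyl.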